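Same exchange on a second core in a transfer protein series

The source may report more compounds than this note shows. Statements on the series, on what has been measured and on what is new or still open speak of the compounds shown alone.

Of the compounds shown here, three of one series have been measured in an assay on isolated protein for inhibition of microsomal triglyceride transfer protein large subunit (Homo sapiens); on this read-out lower numbers stand for stronger inhibition and higher numbers for weaker inhibition. Compound 1 `COC(=O)NCC1Cc2ccc(NC(=O)c3cccc(C)c3-c3ccc(C(F)(F)F)cc3)cc2C1` gives 24 nM there. Compound 2 `Cc1cccc(C(=O)Nc2ccc3c(c2)CC(CNS(=O)(=O)c2cccs2)C3)c1-c1ccc(C(F)(F)F)cc1` gives 14 nM in this assay. Compound 3 `COC(=O)NC1CCc2ccc(NC(=O)c3cccc(C)c3-c3ccc(C(F)(F)F)cc3)cc2CC1` gives 20 nM in this assay. Compound 4 `Cc1cccc(C(=O)Nc2ccc3c(c2)CCC(NS(=O)(=O)c2cccs2)CC3)c1-c1ccc(C(F)(F)F)cc1` is the member still to be measured.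

Compound 1 and compound 2 differ in a single place: (thiophen-2-yl)sulfonyl in place of methoxycarbonyl on an amine nitrogen. The step that went with it is a 1.7-fold lower number from compound 1 to compound 2 (0.23 log units; within the scatter).

The cores of compound 1 and compound 3 are different, and the difference between the two cores is not broken down here. Their values in this assay lie within the scatter of each other, so nothing separates them.

Compound 4 is derived from compound 3 by an exchange of the same kind: (thiophen-2-yl)sulfonyl in place of methoxycarbonyl on an amine nitrogen. The place is not the same word for word: in compound 1 the amine nitrogen has a saturated chain carbon as its other neighbour, while in compound 3 it has a saturated ring carbon, so this is the same kind of change rather than the same change.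

The expectation for compound 4 rests on compound 1 and compound 2, because a 1.7-fold lower number from compound 1 to compound 2 (0.23 log units; within the scatter) was small and within the scatter. The step from compound 3 to compound 4 is therefore expected to be a 1.7-fold lower number from compound 3 to compound 4 (0.22 log units; within the scatter), beside the earlier one. Compound 4 is estimated at 12 nM in this assay, most likely between 5 nM and 30 nM.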

Compound 4, half-maximal inhibitory concentration: 140 nM
For compound 4 the middle estimate is 12-fold (1.07 log units) below the measured one; measured number above the stated range.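

In this assay, the exchange of methoxycarbonyl for (thiophen-2-yl)sulfonyl on the amine nitrogen gives a 7.0-fold higher number from compound 3 to compound 4 (0.85 log units; beyond the scatter), so on this core the change costs inhibition, and its outcome on the core of compound 1 did not carry over: the same change on two cores in this assay, a 1.7-fold lower number (0.23 log units; within the scatter) from compound 1 to compound 2 and a 7.0-fold higher number (0.85 log units; beyond the scatter) from compound 3 to compound 4, 12-fold (1.08 log units) apart, beyond the scatter of two such steps. In this pair of cores, then, the result of the exchange depends on its surroundings, and a step read on one core is a poor guide to the same step on the other. It does not show which difference is responsible, whether the core itself or the amine nitrogen sitting on a saturated ring carbon rather than a saturated chain carbon, since these two differences go together in the compounds shown, and with only two pairs no rule can be drawn for the series.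

On these data alone, what remains open is whether other groups on the nitrogen, such as methanesulfonyl, benzenesulfonyl or acetyl, would also behave differently on the two cores. As far as these compounds go, it is also open whether a one-carbon chain that carries the amine nitrogen on the core of compound 3 would let the (thiophen-2-yl)sulfonyl group be tolerated there.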